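Trading methoxy for chloro on the benzyl group

The source may report more compounds than this note shows. Statements on the series, on what has been measured and on what is new or still open speak of the compounds shown alone.

Among the measured compounds shown here, in an ADME assay on HEK-293T cells (Homo sapiens) for inhibition, read by CCK-8 assay, with a stated time of 48 h, tested at 20 uM (a higher number here means more inhibition of growth at the concentration tested, a lower number less inhibition of growth), compound 1 (`COc1ccc(Cc2nnc(NC(=O)/C(C#N)=C/c3ccccc3OS(=O)(=O)c3ccc(OC)cc3)s2)cc1`) gives 30%, the higher of the two numbers known so far, and compound 2 (`COc1ccc(Cc2nnc(NC(=O)/C(C#N)=C/c3ccccc3OS(=O)(=O)c3ccc([N+](=O)[O-])cc3)s2)cc1`) gives 17%. Compound 3 (`COc1ccc(S(=O)(=O)Oc2ccccc2/C=C(\C#N)C(=O)Nc2nnc(Cc3ccc(Cl)cc3)s2)cc1`) differs from compound 1 in one place: chloro in place of methoxy on an aromatic carbon. Chloro takes the place of methoxy on an aromatic carbon, turning 4-methoxybenzyl into 4-chlorobenzyl.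

For the measured compounds named here, only one measured step bears on this change: a number 13 percentage points lower from compound 1 to compound 2 (beyond the scatter). There, nitro replaced the other methoxy group of compound 1, so this step is only a loose guide, with a different incoming group at a different site. No shift beyond the scatter is therefore expected in this assay, although a modest move either way remains possible. The estimated change is a number 2 percentage points lower from compound 1 to compound 3 (within the scatter). For compound 3, the expected value is 28%, within an estimated range of 12% to 48%.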

Compound 3, percent growth inhibition at one concentration: 26%
For compound 3 the middle estimate is 2 percentage points above the measured one; measured number inside the range.
By their numbers in this assay, from the lowest: compounds 2, 3 and 1 (each within the scatter of the next, the first and the last beyond it).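

Putting chloro in place of methoxy on the benzyl group gives a number 4 percentage points lower from compound 1 to compound 3 (within the scatter) in this assay. Among the compounds shown here, this is the first look at this position, and it shows that the methoxy group of the 4-methoxybenzyl part can be exchanged without a shift that stands clear of the usual scatter, whereas the only earlier step, with nitro at the other methoxy group, gave a number 13 percentage points lower from compound 1 to compound 2 (beyond the scatter). Nothing available explains why the reading stays within the scatter here.

From the compounds shown here alone, whether an amine, a carboxylic acid or a longer chain at this spot on the benzyl group would move the number remains open. Also open, going by these compounds, is what chloro would do at the other methoxy group, and what nitro would do on the benzyl group, so the effects of group and site cannot yet be separated.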